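A few compounds are considered here, and "the series" means these few. Any claim that something is new, unique, unknown or untested is made for them only; others in the source may bear on it.

Measured compounds:
compound 1 `CNS(=O)(=O)c1cn(Cc2nc3cc(Cl)ccc3n2CCCS(C)(=O)=O)c2ccccc12`: an ADME assay on HEp-2 cells (Homo sapiens) for cytotoxicity, with a stated time of 4 days; a higher number here means that more compound is tolerated, a lower number that less compound is tolerated > 100000 nM
compound 2 `CS(=O)(=O)CCCn1c(Cn2nc(S(C)(=O)=O)c3ccccc32)nc2cc(Cl)ccc21`: > 100000 nM
compound 3 `CS(=O)(=O)c1nn(Cc2nc3cc(Cl)ccc3n2CCCO)c2cnccc12`: > 100000 nM

The value of compound 1 is a limit of the assay and not a number. The value of compound 2 is likewise a limit. Compound 3 also stands at a limit, so no true position within the series can be given for it: the limit of > 100000 nM in this assay, at which 3 of the 3 values shown sit. Compound 4 `CS(=O)(=O)c1nn(Cc2nc3cc(Cl)ccc3n2CCC(F)(F)F)c2cnccc12` follows from compound 3 by one change: trifluoromethyl in place of hydroxymethyl on a saturated chain carbon, two bonds along the chain from an aromatic nitrogen. Going by the values given here, no measured pair differs in only this place, so no step in this assay is known for such a change. The expectation is that the step from compound 3 to compound 4 in this assay stays within the scatter, with no movement beyond it, so a number no higher from compound 3 to compound 4 (the limit leaves the size open) is the expected step. For compound 4 in this assay the estimate is 100000 nM, with a range from 30000 nM to 300000 nM, and most likely again a limit rather than a number.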

Compound 4, half-maximal cytotoxic concentration in the HEp-2 assay: > 100000 nM
Compound 4 gave a limit, no number; the forecaster's own chance of this, stated with the estimate: 70%; the middle value sits exactly at the limit.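

In the HEp-2 assay compound 3 gives > 100000 nM, which is a limit and not a number. Going by these compounds alone, in the HEp-2 assay compound 4 gives > 100000 nM, which is also a limit and not a number, so no step between them can be read. The compounds shown leave open where any of them would give a true number in the HEp-2 assay. In a physicochemical assay for solubility, read by spectrophotometry, in phosphate buffer, at pH 6.5 (on this read-out higher numbers stand for higher solubility and lower numbers for lower solubility), compound 3 gives 40 ug/mL and compound 4 gives 3 ug/mL. In the physicochemical assay the change of trifluoromethyl in place of hydroxymethyl is a 13-fold lower number from compound 3 to compound 4 (1.12 log units; beyond the scatter).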